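The source may hold more compounds than are shown below. What is called first, only, known or untested is meant among the compounds shown, and "the series" means these compounds.

The measured compounds:
- compound 1, `CC(CC(=O)O)CC(=O)c1c(CCCCCCc2ccccc2)n(C)c2ccc(Cl)cc12`, gives 0.28 nM in a functional assay for antagonist activity at Oxoeicosanoid receptor 1 (Homo sapiens), read by fluorescence and calcium flux, with stated times of 2 min and 1 min; on this read-out lower numbers stand for stronger inhibition and higher numbers for weaker inhibition
- compound 2, `C[C@H](CC(=O)O)CC(=O)c1c(CCCCCCc2ccccc2)n(C)c2ccc(Cl)cc12`, gives 0.12 nM
- compound 3, `CC(CC(=O)O)CC(=O)c1c(CCCCc2ccccc2)n(C)c2ccc(Cl)cc12`, gives 38 nM

Compound 2 gives the lowest number of the three. Its nearest neighbour is compound 1, separated from it by a 2.3-fold lower number from compound 1 to compound 2 (0.37 log units; beyond the scatter), a step that rests on (the fact that one of compounds 1 and 2 is drawn with a defined configuration and the other without, at the place where they differ). Compound 3 lies furthest away, and the step of a 140-fold higher number from compound 1 to compound 3 (2.13 log units; beyond the scatter) shows how strongly the shorter chain raises the number.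

Compound 4, `C[C@H](CC(=O)O)CC(=O)c1c([C@H](O)CCCCCc2ccccc2)n(C)c2ccc(Cl)cc12`, differs from compound 2 by hydroxy in place of hydrogen on a saturated chain carbon bound to an aromatic carbon and a saturated chain carbon. Among the compounds with values here, neither measured step touches this place: one concerns only the drawn configuration, the other only the length of the chain, so no measured step bears directly on the change. The expectation for compound 4 therefore leans on compound 2 alone, and a step of no more than modest size in either direction is expected, a 3.3-fold higher number from compound 2 to compound 4 (0.52 log units; beyond the scatter). Compound 4 is estimated at 0.4 nM, in a range from 0.06 nM to 3 nM.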

Compound 4, half-maximal inhibitory concentration: 260 nM
Estimate against measurement, compound 4: 650-fold (2.81 log units) below; measured number above the stated range.
By their numbers in this assay, from the lowest: compound 2; then compound 1; then compound 3; then compound 4.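

Within the data shown here, until now, the only structural change with a large effect was the shorter chain, and compound 2 gave no sign that the saturated chain carbon bound to an aromatic carbon and a saturated chain carbon was sensitive to substitution. In this assay, that carbon proves highly sensitive: hydroxy in place of hydrogen gives a 2200-fold higher number from compound 2 to compound 4 (3.34 log units; beyond the scatter), a larger step than the one produced by shortening the chain, a 140-fold higher number from compound 1 to compound 3 (2.13 log units; beyond the scatter). Nothing in the data shown accounts for this rise.

The compounds shown leave open whether the rise belongs to hydroxy itself or to the configuration drawn at that carbon, as they include only one hydroxy compound. The opposite configuration of the hydroxy group, or a methoxy group or fluorine at the same carbon, would help separate these possibilities.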